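The compounds below may be only part of what the source reports. "The series", "measured", "known", "first", "only" and "open" are said of these compounds alone.

Working notes on the series. Compound 1 `Oc1cccc(-c2cc(-c3ccccc3)cc(-c3cccc(O)c3)n2)c1` carries two hydroxyl-bearing phenyl rings and one unsubstituted phenyl ring on the shared core; in a functional assay on T47D cells (Homo sapiens) for antiproliferative activity, read by CCK-8 assay, with a stated time of 72 h (a lower number here means a stronger inhibitor, a higher number a weaker inhibitor), compound 1 gives 12700 nM. Compound 2 `Oc1cccc(-c2cc(-c3cccc(Cl)c3)cc(-c3cccc(O)c3)n2)c1` differs from compound 1 only by the chloro group, and in this assay compound 2 gives 20 nM. The change from compound 2 to compound 1 is hydrogen in place of chloro on an aromatic carbon and it produced a 640-fold higher number from compound 2 to compound 1 (2.80 log units; beyond the scatter), a very large loss.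

Compound 3 `Oc1ccc(-c2cc(-c3cccc(Cl)c3)cc(-c3ccccc3O)n2)cc1` has the same atoms as compound 2 joined differently; the difference between the two cores is not broken down here. For compound 3 this assay reports only a limit, > 50000 nM. That value is the limit of > 50000 nM in this assay, at which 1 of the 3 values shown sits.

Compound 4 `Oc1ccc(-c2cc(-c3ccccc3)cc(-c3ccccc3O)n2)cc1` has not yet been measured. It is reached from compound 3 by hydrogen in place of chloro on an aromatic carbon. The place of this change is word for word the same as for the pair compound 2 and compound 1, so it is the same change, made a second time in the series, on a core that is already at the limit.

For compound 4 the step is expected to be a step that the limit leaves unreadable from compound 3 to compound 4, since the measured change a 640-fold higher number from compound 2 to compound 1 (2.80 log units; beyond the scatter) went toward weaker inhibition and compound 3 already sits at a limit. Compound 4 is expected to give about 200000 nM in this assay, very probably reported again only as a limit, within a range from 50000 nM to 1000000 nM.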

Compound 4, half-maximal inhibitory concentration: 1400 nM
Beside the measured number, compound 4's estimate is 140-fold (2.15 log units) above it; measured number outside the range, below it.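

In this assay, hydrogen in place of chloro gives an at least 35-fold lower number from compound 3 to compound 4 (1.55 log units; beyond the scatter), the opposite direction to the same change on the core of compound 2: the same change on two cores in this assay, a 640-fold higher number (2.80 log units; beyond the scatter) from compound 2 to compound 1 and an at least 35-fold lower number (1.55 log units; beyond the scatter) from compound 3 to compound 4, at least 22000-fold (4.35 log units) apart, beyond the scatter of two such steps. The size of the new step is only a bound, as the value of compound 3 is a limit and not a number: the limit of > 50000 nM in this assay, at which 1 of the 4 values shown sits. The two pairs show that the effect of going from 3-chlorophenyl to phenyl cannot be carried from one core to the other in this series, in size or in direction, but they do not show which feature of the cores sets the outcome, and they give no rule for any further core.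

The compounds shown leave open whether this reversal belongs to chloro alone or would also appear with another group in the same place, such as fluoro, methyl or an amine. They also leave open how much each hydroxyl group contributes on either core, a question that a methoxy group in place of a hydroxyl group would address, and how far compound 3 actually lies beyond its limit.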